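A few compounds are considered here, and "the series" means these few. Any claim that something is new, unique, unknown or untested is made for them only; others in the source may bear on it.

Values in a physicochemical assay, read by spectrophotometry, with a stated time of 30 min (on this read-out higher numbers stand for weaker inhibition and lower numbers for stronger inhibition), so far
- compound 1 `O=C(CC(c1ccc(Cl)cc1)c1c[nH]c2ccccc12)c1c(O)c2ccccc2oc1=O` gives 46.4 ug/mL
- compound 2 `O=C(CC(c1c(Cl)cccc1Cl)c1c[nH]c2ccccc12)c1c(O)c2ccccc2oc1=O` gives 13.5 ug/mL
- compound 3 `COc1ccc(C(CC(=O)c2c(O)c3ccccc3oc2=O)c2c[nH]c3ccccc23)cc1OC` gives 63.2 ug/mL

The three differ only in the aryl group on a saturated chain carbon bound to an aromatic carbon and a saturated chain carbon. Compound 3 is level in practice with one neighbour and apart from the other, the series showing a 1.4-fold higher number from compound 1 to compound 3 (0.13 log units; within the scatter) and a 4.7-fold higher number from compound 2 to compound 3 (0.67 log units; beyond the scatter) on these numbers. The remaining gap at this place is a 3.4-fold lower number from compound 1 to compound 2 (0.54 log units; beyond the scatter) in the same read-out.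

Next is compound 4 `O=C(CC(c1ccc(O)c(O)c1)c1c[nH]c2ccccc12)c1c(O)c2ccccc2oc1=O`, with the change 3,4-dihydroxyphenyl in place of 3,4-dimethoxyphenyl on a saturated chain carbon bound to an aromatic carbon and a saturated chain carbon at that same place: 3,4-dihydroxyphenyl in place of 3,4-dimethoxyphenyl. Among the measured compounds shown here, no measured step makes this swap, so the measured steps serve only to show how far this place can move the number, and the largest of them is modest. The entering group carries hydrogen-bond donors and the leaving group none. A lower number is expected, with its size taken from the reach seen in a 4.7-fold higher number from compound 2 to compound 3 (0.67 log units; beyond the scatter) at this place. The expected move is a 4.5-fold lower number from compound 3 to compound 4 (0.65 log units; beyond the scatter) as an estimate, with wide uncertainty. Compound 4 is estimated at 14 ug/mL within an expected range of 4 ug/mL to 45 ug/mL in this read-out.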

Compound 4, half-maximal inhibitory concentration: 71.1 ug/mL
Compound 4: middle estimate off by 5.1-fold (0.71 log units), on the low side; the measured number lies above the stated range.
By their numbers in this assay, from the lowest: compound 2; then compounds 1, 3 and 4 (each within the scatter of the next).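

In this assay, 3,4-dihydroxyphenyl in place of 3,4-dimethoxyphenyl on the saturated chain carbon gives a 1.1-fold higher number from compound 3 to compound 4 (0.05 log units; within the scatter), so a group with hydrogen-bond donors and one without them stand level at this place. Among the compounds shown here, the same holds against 4-chlorophenyl, with a 1.5-fold higher number from compound 1 to compound 4 (0.19 log units; within the scatter), while a 5.3-fold higher number from compound 2 to compound 4 (0.72 log units; beyond the scatter) leaves 2,6-dichlorophenyl as the only group of the four set apart, so that compound 2 has the lowest number, beyond the scatter from each of the others, and compounds 1, 3 and 4 form one level group despite their different aryl groups. No measurement bearing on why these aryl groups read as they do is at hand.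

Still open, going by these compounds, is whether the separation of compound 2 goes with the two chlorines as such or with any group of that pattern, which a 2,6-dimethylphenyl or 2,6-difluorophenyl group at this place would help to settle. Also open, on these data alone, is whether the level reading of the other three extends to aryl groups bearing an amine or a carboxylic acid, or to a cyclohexyl group in place of the aromatic ring.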